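This account rests on a few compounds, and the source may have more. Where it says the series, first, only, none or still open, it means among the compounds named here.

Measured so far:
compound 1 `C(=C/c1nc2ccccn2c1Sc1ccccc1)\c1ccccc1`: 8800 nM
compound 2 `c1ccc(Sc2c(-c3cccs3)nc3ccccn23)cc1`: 17100 nM

Both values come from a functional assay on HepG2 cells (Homo sapiens) for inhibition, read by MTT assay, with a stated time of 48 h; on this read-out higher numbers stand for weaker inhibition and lower numbers for stronger inhibition. On these numbers, compound 2 cannot be told apart from compound 1. The next compound is compound 3 `c1ccc(Sc2c(-c3ccsc3)nc3ccccn23)cc1`, and the change is thiophen-3-yl in place of thiophen-2-yl on an aromatic carbon. The two have the same atoms, joined differently: thiophen-3-yl in place of thiophen-2-yl on an aromatic carbon. Going by the values given here, only one measured step bears on this, at that same aromatic carbon but with a different group leaving: a 1.9-fold higher number from compound 1 to compound 2 (0.29 log units; within the scatter). Among the compounds with values here, no measured pair compares thiophen-2-yl with thiophen-3-yl directly. With compound 2 at 17100 nM as the anchor, no step beyond the scatter is expected in this assay, in either direction. The expected step is a 1.2-fold lower number from compound 2 to compound 3 (0.09 log units; within the scatter). The estimate for compound 3 is 14000 nM, with an expected range of 6000 nM to 32000 nM.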

Compound 3, half-maximal inhibitory concentration: 49600 nM
Compound 3: middle estimate off by 3.5-fold (0.55 log units), on the low side; the whole stated range lies below it.
By their numbers in this assay, from the lowest: compounds 1 and 2 (each within the scatter of the next); then compound 3.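

In this assay, going by these compounds alone, this aromatic carbon proves sensitive to how the thiophene is attached: with the same atoms on both sides, thiophen-3-yl in place of thiophen-2-yl gives the first step beyond the scatter (a 2.9-fold higher number from compound 2 to compound 3 (0.46 log units; beyond the scatter)). Measured against the 2-phenylethenyl group, thiophen-3-yl also separates (a 5.6-fold higher number from compound 1 to compound 3 (0.75 log units; beyond the scatter)), whereas thiophen-2-yl could not be told apart from that group. Nothing at hand accounts for the difference between the two thiophene attachments.

Still open, on these data alone, is how this carbon responds to a pyridine ring, an amine or a saturated alkyl chain in place of the thiophene. Also open, as far as these compounds go, is whether the gap between thiophen-2-yl and thiophen-3-yl persists when another group, such as a benzyl group, replaces the phenylsulfanyl group.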